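Changing the Aryl Group on an Aromatic Nitrogen

The source may hold more compounds than are shown below. What is called first, only, known or untested is meant among the compounds shown, and "the series" means these compounds.

Of the compounds shown here, three built on one shared core have been tested in a functional assay on HCT-116 cells (Homo sapiens) for antiproliferative activity, read by MTT assay, with a stated time of 48 h; a higher number here means a weaker inhibitor, a lower number a stronger inhibitor. Compound 1 `N#CC1=C(N)Oc2c(N)cc3nc4ccccc4nc3c2C12C(=O)N(Cc1cnnn1-c1cccc(C(F)(F)F)c1)c1ccccc12` gives 18900 nM in this assay. Compound 2 `Cc1cc(C)cc(-n2nncc2CN2C(=O)C3(C(C#N)=C(N)Oc4c(N)cc5nc6ccccc6nc5c43)c3ccccc32)c1` reaches only the assay limit, with a value of > 50000 nM in this assay. Compound 3 `N#CC1=C(N)Oc2c(N)cc3nc4ccccc4nc3c2C12C(=O)N(Cc1cnnn1-c1ccc(F)c(Cl)c1)c1ccccc12` likewise stands at the assay limit, > 50000 nM in this assay, so for compound 3 no exact number is known. Two of the three values sit at that bound, as the limit of > 50000 nM in this assay, at which 2 of the 3 values shown sit, records.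

Within the data shown here, two measured steps bear on the aryl group that sits on the aromatic nitrogen: an at least 2.6-fold higher number from compound 1 to compound 2 (0.42 log units; beyond the scatter) and an at least 2.6-fold higher number from compound 1 to compound 3 (0.42 log units; beyond the scatter). Both moves away from 3-(trifluoromethyl)phenyl weakened the compounds. Between the two limits, a step that the two limits leave unreadable from compound 2 to compound 3, so that step cannot be sized.

Compound 4 `N#CC1=C(N)Oc2c(N)cc3nc4ccccc4nc3c2C12C(=O)N(Cc1cnnn1-c1ccc(Cl)cc1[N+](=O)[O-])c1ccccc12` differs from compound 3 in one place: 4-chloro-2-nitrophenyl in place of 3-chloro-4-fluorophenyl on an aromatic nitrogen. Among the measured compounds shown here, no measured step shows a gain from changing this aryl group, and compound 3 begins at the limit, so compound 4 is expected to stay near that limit. The estimate for compound 4 is 50000 nM, within 15000 nM to 200000 nM. The step this implies, a number no higher from compound 3 to compound 4 (the limit leaves the size open), is an expectation only.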

Compound 4, half-maximal inhibitory concentration: 28700 nM
Compound 4: the middle estimate sits 1.7-fold (0.24 log units) above what was measured; the measured number falls inside the stated range.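

Compound 4 shows that a group other than 3-(trifluoromethyl)phenyl on the aromatic nitrogen can still give a measurable number in this assay, whereas the two other replacements ended at the assay limit. Against those two limit compounds, 4-chloro-2-nitrophenyl gives an at least 1.7-fold lower number from compound 3 to compound 4 (0.24 log units; that floor lies within the scatter) and an at least 1.7-fold lower number from compound 2 to compound 4 (0.24 log units; that floor lies within the scatter), so neither step on its own proves a real gain. The third step is a 1.5-fold higher number from compound 1 to compound 4 (0.18 log units; within the scatter), which means these two compounds cannot be told apart and that moving away from 3-(trifluoromethyl)phenyl does not always weaken the compound beyond the scatter.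

The compounds shown do not tell whether the chlorine or the nitro group of compound 4 accounts for its measurable number, a question that 4-chlorophenyl and 2-nitrophenyl at the same place would address, and they say nothing about an aryl group carrying an amine or a carboxylic acid. The true size of the steps from the two limit compounds also stays open because those compounds have no exact number: the limit of > 50000 nM in this assay, at which 2 of the 4 values shown sit.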